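Fluoro on the ketone-side indole and cytotoxicity

This account rests on a few compounds, and the source may have more. Where it says the series, first, only, none or still open, it means among the compounds named here.

Measured so far:
compound 1 `COc1ccc2[nH]cc(/C=C(\C#N)C(=O)c3c[nH]c4ccccc34)c2c1` — 21200 nM
compound 2 `N#C/C(=C\c1c[nH]c2cc(F)ccc12)C(=O)c1c[nH]c2cc(F)ccc12` — > 50000 nM
compound 3 `N#C/C(=C\c1c[nH]c2cc(F)ccc12)C(=O)c1c[nH]c2ccccc12` — 23500 nM

In a functional assay on MIA PaCa-2 cells (Homo sapiens) for cytotoxicity, read by WST assay, with a stated time of 24 h (on this read-out lower numbers stand for stronger inhibition and higher numbers for weaker inhibition), compound 1 gives 21200 nM and compound 3 gives 23500 nM; the two sit within the scatter of each other. For compound 2 the result is a limit of the assay, > 50000 nM, not a number. The step of an at least 2.1-fold higher number from compound 3 to compound 2 (0.32 log units; beyond the scatter) is the change (fluoro in place of hydrogen on an aromatic carbon). The difference between the cores of compound 1 and compound 3 is not broken down here.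

Compound 4 `COc1ccc2[nH]cc(/C=C(\C#N)C(=O)c3c[nH]c4cc(F)ccc34)c2c1` carries the same change relative to compound 1: fluoro in place of hydrogen on an aromatic carbon. Because an at least 2.1-fold higher number from compound 3 to compound 2 (0.32 log units; beyond the scatter) weakened compound 2 beyond the scatter and reached (the limit of > 50000 nM in this assay, at which 1 of the 3 values shown sits), a similar step is expected from compound 1, a 2.1-fold higher number from compound 1 to compound 4 (0.33 log units; beyond the scatter), so compound 4 is estimated at 45000 nM, with a fair chance that only a limit is reported.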

Compound 4, half-maximal inhibitory concentration: > 50000 nM
Compound 4: a limit, no number; the forecaster's own chance of this, stated with the estimate: 45%; at least 1.1-fold (0.04 log units) between middle value and limit.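

For compound 4 the result in this assay is a limit, > 50000 nM, not a number. Fluoro in place of hydrogen on an aromatic carbon gives an at least 2.3-fold higher number from compound 1 to compound 4 (0.37 log units; beyond the scatter), so the change weakens the read-out on both cores shown: the same change on two cores in this assay, an at least 2.1-fold higher number (0.32 log units; beyond the scatter) from compound 3 to compound 2 and an at least 2.3-fold higher number (0.37 log units; beyond the scatter) from compound 1 to compound 4; the limit leaves it open whether they differ This shows that the direction of the change carries from one core to the other, but it does not give the true size of either step, and neither fluoro compound has a number that could be compared with the other: the limit of > 50000 nM in this assay, at which 2 of the 4 values shown sit.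

The compounds shown leave open how other groups on this aromatic carbon would read in this assay, such as chloro, an amine or a carboxylic acid. On these data alone, whether the same direction holds on any further core also stays open.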